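The source may report more compounds than this note shows. Statements on the series, on what has been measured and on what is new or still open speak of the compounds shown alone.

Of the compounds shown here, two have so far been measured in a functional assay on MCF7 cells (Homo sapiens) for cytotoxicity, read by MTT assay, with a stated time of 96 h; on this read-out higher numbers stand for weaker inhibition and lower numbers for stronger inhibition. Compound 1 (`COc1cc(C(=O)c2cn(-c3ccc(N)cc3)cc2-c2ccccc2)cc(OC)c1OC`) gives 35 nM there, and compound 2 (`COc1cc(C(=O)c2cn(-c3ccc(C)cc3)cc2-c2ccccc2[N+](=O)[O-])cc(OC)c1OC`) gives 65 nM there. These two numbers lie within the usual scatter of each other, so compound 2 stands level with compound 1 in this small set.

Compound 3 (`COc1cc(C(=O)c2cn(-c3ccc(N)cc3)cc2-c2ccccc2[N+](=O)[O-])cc(OC)c1OC`) is still unmeasured. It differs from compound 2 by a single change, amino in place of methyl on an aromatic carbon. Among the measured compounds shown here, no measured pair shows this change on its own. For the measured compounds named here, the only guide is compound 1, which also carries a 4-aminophenyl group and gives 35 nM in this assay. A small move towards a lower number is therefore expected, but none beyond the scatter. The estimated step is a 1.6-fold lower number from compound 2 to compound 3 (0.21 log units; within the scatter) and would count as minor. The expected value for compound 3 is 40 nM within an estimated range from 15 nM to 110 nM on this reasoning.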

Compound 3, half-maximal inhibitory concentration: 53 nM
For compound 3 the middle estimate is 1.3-fold (0.12 log units) below the measured one; measured number inside the range.
By their numbers in this assay, from the lowest: compounds 1, 3 and 2 (each within the scatter of the next).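

Exchanging 4-methylphenyl for 4-aminophenyl gives a 1.2-fold lower number from compound 2 to compound 3 (0.09 log units; within the scatter) in this assay, so with the nitro group present, the two groups at this place cannot be told apart in this read-out, even though the amino group adds a hydrogen-bond donor and acceptor that methyl lacks. The second new comparison keeps the 4-aminophenyl group and adds nitro in place of hydrogen, giving a 1.5-fold higher number from compound 1 to compound 3 (0.18 log units; within the scatter), so this change also stays within the scatter. Nothing available explains either result.

On these data alone, it remains open whether the exchange of methyl for amino would give a similar step on the core of compound 1, which has no nitro group. As far as these compounds go, how a hydroxyl group, a carboxylic acid or a longer alkyl chain would read in place of the amino group also remains open.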